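A few compounds are considered here, and "the series" means these few. Any claim that something is new, unique, unknown or untested is made for them only; others in the source may bear on it.

Measured compounds in the series:

compound 1 `CN1CCC(c2c[nH]c3cnc(NC(=O)c4ccc(F)cc4)cc23)CC1` gives 80 nM in an assay for binding affinity to 5-hydroxytryptamine receptor 1B (Homo sapiens), read by radioligand binding; on this read-out higher numbers stand for weaker inhibition and lower numbers for stronger inhibition.
compound 2 `CCCCCCCC(=O)Nc1ccc2[nH]cc(C3CCN(C)CC3)c2n1` gives 32 nM in this assay.
compound 3 `COc1ccccc1C(=O)Nc1ccc2[nH]cc(C3CCN(C)CC3)c2n1` gives 750 nM in this assay.

Compound 3 carries the highest number of the three; the nearest value is that of compound 1, the furthest that of compound 2, and both gaps lie beyond the scatter. Among the compounds with values here, the only single-point step recorded so far, a 23-fold higher number from compound 2 to compound 3 (1.37 log units; beyond the scatter), replaces the heptyl chain with the 2-methoxyphenyl group on the carbonyl carbon and is large. Within the data shown here, no single-point step connects compound 1 and compound 3; their two values simply show that the 4-fluorophenyl amide sits well below the 2-methoxyphenyl amide in this assay.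

Compound 4 `Cc1cccc(C(=O)Nc2ccc3[nH]cc(C4CCN(C)CC4)c3n2)c1` is not yet measured. The change from compound 3 is 3-methylphenyl in place of 2-methoxyphenyl on a carbonyl carbon. The step from compound 2 to compound 3 shows how far an aromatic amide can move the number; the value of compound 1 shows that a different substituted phenyl amide is not obliged to stay at the level of compound 3. Among the measured compounds shown here, compound 4 is therefore expected to come in lower than compound 3 in this assay, with a step of about a 5.0-fold lower number from compound 3 to compound 4 (0.70 log units; beyond the scatter), though the spread of the estimate remains wide because only the step from compound 2 to compound 3 a 23-fold higher number from compound 2 to compound 3 (1.37 log units; beyond the scatter) and the value of compound 1 80 nM inform it. The estimate for compound 4 is 150 nM, within a range of 40 nM to 600 nM.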

Compound 4, inhibition constant: 1200 nM
Estimate against measurement, compound 4: 8.0-fold (0.90 log units) below, and the stated range ends below it.
By their numbers in this assay, from the lowest: compound 2; then compound 1; then compounds 3 and 4 (each within the scatter of the next).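

In this assay the exchange on the carbonyl carbon gives a 1.6-fold higher number from compound 3 to compound 4 (0.20 log units; within the scatter), so at this place the 3-methylphenyl and 2-methoxyphenyl amides cannot be told apart, even though the leaving group has 1 hydrogen-bond acceptor and the entering group has 0. The heptyl amide compound 2 now stands apart from two aromatic amides on the shared core rather than one: alongside a 23-fold higher number from compound 2 to compound 3 (1.37 log units; beyond the scatter) there is a 38-fold higher number from compound 2 to compound 4 (1.57 log units; beyond the scatter), and both steps are large and beyond the scatter. No measurement among the data bears on why these groups give the numbers they do.

Open, as far as these compounds go, is whether a shorter chain, a longer chain, or a chain ending in an amine or a carboxylic acid on the carbonyl carbon would stay near compound 2 or move towards compounds 3 and 4, and whether unsubstituted phenyl would fall with the two aromatic amides. Also open, from the compounds shown here alone, is how the 4-fluorophenyl amide would read on the core of compounds 2, 3 and 4, since compound 1 differs from each of them in more than one place.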